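A few compounds are considered here, and "the series" means these few. Any claim that something is new, unique, unknown or untested is made for them only; others in the source may bear on it.

Compound 1 `O=C1O[C@@H](CN2CCCCC2)CN1c1ccc(-n2cc(-c3ccccn3)cn2)c(F)c1` in an ADME assay on HEK293-A cells (Homo sapiens) for cytotoxicity, read by MTT assay, with a stated time of 48 h (on this read-out lower numbers stand for stronger inhibition and higher numbers for weaker inhibition), gives > 400 ug/mL, a limit of the assay.
Compound 2 `COC[C@H]1CN(c2ccc(-n3cc(-c4ccccn4)cn3)c(F)c2)C(=O)O1` in this assay gives > 400 ug/mL, likewise a limit.
Compound 3 `COC(=O)NC[C@H]1CN(c2ccc(-n3cc(-c4ccccn4)cn3)c(F)c2)C(=O)O1` in this assay gives 306 ug/mL.

Among the measured compounds shown here, compound 3 is thus the only member with a number; the other two sit at the limit of > 400 ug/mL in this assay, at which 2 of the 3 values shown sit. The steps of an at least 1.3-fold lower number from compound 1 to compound 3 (0.11 log units; that floor lies within the scatter) and an at least 1.3-fold lower number from compound 2 to compound 3 (0.11 log units; that floor lies within the scatter) are floors only and lie within the scatter, and a step that the two limits leave unreadable from compound 1 to compound 2 cannot be read between two limits. Compound 4 `CNC(=O)[C@H]1CN(c2ccc(-n3cc(-c4ccccn4)cn3)c(F)c2)C(=O)O1` carries methylcarbamoyl in place of ((methoxycarbonyl)amino)methyl on a saturated ring carbon. For the measured compounds named here, none of the measured steps touches that ring carbon, and none of them reaches beyond the scatter, so no shift beyond the scatter is expected for compound 4. Estimate for compound 4: 360 ug/mL (range 200 ug/mL to 600 ug/mL). The expected step is a 1.2-fold higher number from compound 3 to compound 4 (0.07 log units; within the scatter).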

Compound 4, half-maximal inhibitory concentration: 342 ug/mL
For compound 4 the middle estimate is 1.1-fold (0.02 log units) above the measured one; the range from low to high includes it.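

Among the compounds shown here, at the saturated ring carbon next to the ring oxygen, methylcarbamoyl in place of ((methoxycarbonyl)amino)methyl gives, in this assay, a 1.1-fold higher number from compound 3 to compound 4 (0.05 log units; within the scatter), the first step with a number at both ends. Against the other two compounds, the change gives only floors: an at least 1.1-fold lower number from compound 2 to compound 4 (0.06 log units; that floor lies within the scatter) and an at least 1.1-fold lower number from compound 1 to compound 4 (0.06 log units; that floor lies within the scatter). These comparisons stay floors because their starting values are limits: the limit of > 400 ug/mL in this assay, at which 2 of the 4 values shown sit.

On these data alone, whether a carboxylic acid or a primary amine at this ring carbon would move the number beyond the scatter stays open. The same holds for a longer chain carrying the amide.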